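The source may report more compounds than this note shows. Statements on the series, on what has been measured and on what is new or still open speak of the compounds shown alone.

Among the measured compounds shown here, compound 3 `CC(C)(C)C(=O)OC(CSc1[nH]cnc2ncnc1-2)CN1CCN(C(c2ccc(F)cc2)c2ccc(F)cc2)CC1` stands second highest of the three compounds measured so far in a functional assay on muscle tissue (Mustela putorius furo); a lower number here means a smaller maximal response, a higher number a larger maximal response: compound 3 gives 43%, a value with no order to compound 2 `CC(=O)Oc1ccccc1C(=O)OC(CSc1[nH]cnc2ncnc1-2)CN1CCN(C(c2ccc(F)cc2)c2ccc(F)cc2)CC1`, which in this assay gives 34%, since the difference a number 9 percentage points higher from compound 2 to compound 3 (within the scatter) lies within the scatter. Far above both sits compound 1 `CC(=O)OC(CSc1[nH]cnc2ncnc1-2)CN1CCN(C(c2ccc(F)cc2)c2ccc(F)cc2)CC1`, which in this assay gives 248%; the steps of a number 214 percentage points lower from compound 1 to compound 2 (beyond the scatter) and a number 205 percentage points lower from compound 1 to compound 3 (beyond the scatter) are both large and beyond the scatter.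

Compound 4 `O=S(=O)(O)OC(CSc1[nH]cnc2ncnc1-2)CN1CCN(C(c2ccc(F)cc2)c2ccc(F)cc2)CC1` differs from compound 3 in one place: sulfo in place of (tert-butyl)carbonyl on an oxygen on a saturated carbon. The measured steps all change the group on a carbonyl carbon, while the sulfo group in compound 4 takes the place of the entire (tert-butyl)carbonyl group, so none of them bears directly on this change. What the measured compounds show is that the smallest group, methyl in compound 1, stands far above the two larger groups, and that the two larger groups are indistinguishable. For the measured compounds named here, a sulfo group is smaller than tert-butyl carbonyl by the count given, so a rise toward compound 1 is conceivable, but with no direct precedent the expected step of a number 47 percentage points higher from compound 3 to compound 4 (beyond the scatter) is uncertain. Compound 4 is therefore estimated at 90%, with a wide range from 30% to 250%.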

Compound 4, largest response reached (reported as maximum), in percent of the reference or control that the assay uses: 57%
Estimate against measurement, compound 4: 33 percentage points above, within the range that was stated.
By their numbers in this assay, from the lowest: compounds 2 and 3 (each within the scatter of the next); then compound 4; then compound 1.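

In this assay, sulfo on an oxygen on a saturated carbon gives a number 14 percentage points higher from compound 3 to compound 4 (beyond the scatter) and a number 23 percentage points higher from compound 2 to compound 4 (beyond the scatter), so this group stands modestly but measurably above both esters, which themselves cannot be ordered. Against the acetyl group the same change gives a number 191 percentage points lower from compound 1 to compound 4 (beyond the scatter), a large step that leaves compound 4 much nearer to compound 2 and compound 3 than to compound 1. This position therefore also tolerates a group that has no carbonyl carbon, while among the four compounds only compound 1, with acetyl, reaches a very large maximal response, and no measurement at hand explains the steps.

The compounds shown leave open whether that large response is peculiar to acetyl or would also appear with a formyl or propanoyl group on this oxygen, which would show how narrowly it depends on the acyl chain. They also leave open where the free hydroxyl would stand on this saturated carbon, and whether a phosphono group would behave like sulfo.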